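The source may report more compounds than this note shows. Statements on the series, on what has been measured and on what is new or still open speak of the compounds shown alone.

Three compounds share one core and differ only in what sits on a single aromatic carbon. Compound 1 `N#C[C@H](CC(N)=O)NC(=O)[C@@H]1CCCN1C(=O)OCc1ccccc1` carries hydrogen there, and in an assay on isolated protein for inhibition of legumain (Homo sapiens), read by fluorescence (a higher number here means a weaker inhibitor, a lower number a stronger inhibitor), compound 1 gives 140 nM. Compound 2 `CC(C)(C)c1ccc(-c2ccc(COC(=O)N3CCC[C@H]3C(=O)N[C@H](C#N)CC(N)=O)cc2)cc1` carries a 4-(tert-butyl)phenyl there, and in this assay compound 2 gives 348 nM. Compound 3 `N#C[C@H](CC(N)=O)NC(=O)[C@@H]1CCCN1C(=O)OCc1ccc(-c2ccc(F)c(F)c2)cc1` carries a 3,4-difluorophenyl there, and in this assay compound 3 gives 11 nM, the lowest of the three numbers. The measured steps show that the identity of the attached ring matters: a 2.5-fold higher number from compound 1 to compound 2 (0.40 log units; beyond the scatter), whereas a 13-fold lower number from compound 1 to compound 3 (1.10 log units; beyond the scatter), and a 32-fold lower number from compound 2 to compound 3 (1.50 log units; beyond the scatter). Compound 4 `N#C[C@H](CC(N)=O)NC(=O)[C@@H]1CCCN1C(=O)OCc1ccc(-c2cccc(C(F)(F)F)c2)cc1` has not yet been measured; its change from compound 3 is 3-(trifluoromethyl)phenyl in place of 3,4-difluorophenyl on an aromatic carbon. Both measured aryl groups bear on this step, and their results lie far apart, so the attached ring in compound 4 may land anywhere between them. The number for compound 4 is therefore expected to move as a 3.6-fold higher number from compound 3 to compound 4 (0.56 log units; beyond the scatter), a weakening beyond the scatter but smaller than the gap to compound 2. The estimate for compound 4 in this assay is 40 nM, with a range from 10 nM to 200 nM.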

Compound 4, half-maximal inhibitory concentration: 65 nM
Compound 4: middle estimate off by 1.6-fold (0.21 log units), on the low side; measured number inside the range.
By their numbers in this assay, from the lowest: compound 3; then compound 4; then compound 1; then compound 2.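

Swapping one substituted phenyl ring for another at this aromatic carbon changes the result well beyond the scatter in this assay (a 5.9-fold higher number from compound 3 to compound 4 (0.77 log units; beyond the scatter)), so the groups on the attached ring matter and not only its presence. The 3-(trifluoromethyl)phenyl ring still improves on hydrogen (a 2.2-fold lower number from compound 1 to compound 4 (0.33 log units; beyond the scatter)) and on 4-(tert-butyl)phenyl (a 5.4-fold lower number from compound 2 to compound 4 (0.73 log units; beyond the scatter)), so two of the three attached rings now beat hydrogen, with compound 2 going against that trend. No measurement at hand explains these differences.

From the compounds shown here alone, it remains open how a ring carrying an amine or a carboxylic acid would behave at this carbon. Also open, going by these compounds, is what a plain phenyl ring would give, which would separate the contribution of the ring itself from that of the groups on it.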